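From Hydroxyethyl to Hydroxymethyl: Compound 4 in Prospect

The compounds below may be only part of what the source reports. "The series", "measured", "known", "first", "only" and "open" are said of these compounds alone.

Of the compounds shown here, three sharing one core have been measured. Compound 1 `COc1nc2ccc(Br)cc2cc1C(c1ccccc1)n1cc(-c2ccc(Br)cc2)nn1` gives 7.43% in an ADME assay on PC-3 cells (Homo sapiens) for cytotoxicity, read by sulforhodamine B assay, with a stated time of 48 h, tested at 10 uM (on this read-out lower numbers stand for less inhibition and higher numbers for more inhibition at the one concentration tested (going by the name of the read-out)), compound 2 `CCCCCCCCc1cn(C(c2ccccc2)c2cc3cc(Br)ccc3nc2OC)nn1` gives 2.27%, and compound 3 `COc1nc2ccc(Br)cc2cc1C(c1ccccc1)n1cc(CCO)nn1` gives 15.5%. Compound 3 thus holds the highest of the three numbers, though its nearest neighbour, compound 1, sits within the scatter of it: a number 8.1 percentage points higher from compound 1 to compound 3 (within the scatter). For the measured compounds named here, only one step is beyond the scatter, a number 13.2 percentage points higher from compound 2 to compound 3 (beyond the scatter), while a number 5.2 percentage points lower from compound 1 to compound 2 (within the scatter).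

Compound 4 `COc1nc2ccc(Br)cc2cc1C(c1ccccc1)n1cc(CO)nn1` is the next compound. Relative to compound 3 the change is hydroxy in place of hydroxymethyl on a saturated chain carbon bound to an aromatic carbon. The measured step that comes closest is a number 13.2 percentage points higher from compound 2 to compound 3 (beyond the scatter), where a hydroxy replaced a hexyl; here a hydroxy replaces a hydroxymethyl, and both groups carry a hydrogen-bond donor and a hydrogen-bond acceptor. The step of a number 8.1 percentage points higher from compound 1 to compound 3 (within the scatter) also stayed within the scatter. The step from compound 3 to compound 4 is therefore expected to be small, a number 2.5 percentage points lower from compound 3 to compound 4 (within the scatter), with no direction beyond the scatter. Compound 4 is estimated at 13% in this assay, within the range 3% to 25%.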

Compound 4, a percentage reported as inhibition, at one concentration (the size of the read-out at that concentration, not a potency): 4.65%
The estimate for compound 4 lay 8.4 percentage points above the measured number; the range from low to high includes it.
By their numbers in this assay, from the lowest: compounds 2, 4, 1 and 3 (each within the scatter of the next, the first and the last beyond it).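

In this assay, the step from 2-hydroxyethyl to hydroxymethyl proves not to be neutral: the computed count of hydrogen-bond donors and acceptors stays the same and one carbon leaves, yet the result is a number 10.9 percentage points lower from compound 3 to compound 4 (beyond the scatter). Hydroxymethyl also does not set compound 4 apart from the compounds without a hydroxy, with a number 2.4 percentage points higher from compound 2 to compound 4 (within the scatter) and a number 2.8 percentage points lower from compound 1 to compound 4 (within the scatter). Compound 4 therefore goes against any pattern tying a hydroxy on this chain to a higher number, and among these compounds the step beyond the scatter from octyl holds for 2-hydroxyethyl only.

Nothing shown explains why the loss of one carbon moves the number here. Going by these compounds, it remains open how a 3-hydroxypropyl chain, an amine or a carboxylic acid would read at this place.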